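Swapping Ring Groups from Compound 1 to Compound 4

This account rests on a few compounds, and the source may have more. Where it says the series, first, only, none or still open, it means among the compounds named here.

Of the compounds shown here, three built on one shared core have been measured in a physicochemical assay for lipophilicity, at pH 7.4; a higher number here means a more lipophilic compound, a lower number a more polar compound. Compound 1 `CCc1ccc(N(CC(C)C)S(=O)(=O)c2ccc3c(c2)C(O)CC(C2CCN(S(C)(=O)=O)CC2)O3)cc1` gives 3.22, the lowest of the three numbers. Compound 3 `CCc1ccc(N(CC(C)C)S(=O)(=O)c2ccc3c(c2)C(O)C[C@H](C2CCOCC2)O3)cc1` gives 4.12. That number is the nearest to compound 1 and still lies beyond the usual scatter above it. Compound 2 `CCc1ccc(N(CC(C)C)S(=O)(=O)c2ccc3c(c2)CCC3OC2CCOCC2)cc1` gives 4.96, the number furthest from compound 1, again beyond the scatter.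

Compound 4 `CCc1ccc(N(CC(C)C)S(=O)(=O)c2ccc3c(c2)C(O)CC(CC2CCOCC2)O3)cc1` has not yet been measured. It differs from compound 1 in a single place: (oxan-4-yl)methyl in place of 1-(methylsulfonyl)piperidin-4-yl on a saturated ring carbon. Among the measured compounds shown here, no two measured compounds differ in exactly this way, so the size of the step has to be judged from what the three numbers show. Compound 3 is the closest guide, because it gives 4.12 while carrying a related oxan-4-yl group, and that sits well above compound 1.

The step from compound 1 to compound 4 in this assay is therefore expected to be upward and clearly beyond the scatter, roughly a number 1.28 log units higher from compound 1 to compound 4 (beyond the scatter). For compound 4 the expected value is 4.5, with a likely range from 4.1 to 4.9.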

Compound 4, distribution coefficient: 4.44
Compound 4: middle estimate off by 0.06 log units, on the high side; the measured number falls inside the stated range.
By their numbers in this assay, from the lowest: compound 1; then compound 3; then compound 4; then compound 2.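

In this assay, placing (oxan-4-yl)methyl instead of 1-(methylsulfonyl)piperidin-4-yl on this saturated ring carbon gives a number 1.22 log units higher from compound 1 to compound 4 (beyond the scatter), the first measured change made in one place only in this series. The size of that step shows that this position, next to the ring oxygen, can shift the number strongly while the rest of compound 1 stays the same. The swap replaces a group of 10 heavy atoms and 2 hydrogen-bond acceptors with one of 7 heavy atoms and 1 hydrogen-bond acceptor, but no measurement here links the step to any single feature of that swap.

The compounds shown leave open where the number would fall with a plain piperidin-4-yl group, which keeps the ring nitrogen without the methylsulfonyl, or with a [1-(methylsulfonyl)piperidin-4-yl]methyl group, which keeps the methylsulfonyl and adds a carbon link to the ring. Either group, on the same ring carbon, would split this one large step into smaller parts that could each be read separately.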